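The source may hold more compounds than are shown below. What is called first, only, known or untested is meant among the compounds shown, and "the series" means these compounds.

Of the compounds shown here, three built on a shared core have been measured in an assay on RBL-1 cells with Polyunsaturated fatty acid 5-lipoxygenase (Rattus norvegicus) as the target; on this read-out higher numbers stand for weaker inhibition and lower numbers for stronger inhibition. Compound 1 `CCOc1ccc(Cc2ccc3ccccc3c2O)cc1` gives 62 nM, compound 2 `Oc1c(Cc2cccc(Cl)c2)ccc2ccccc12` gives 52 nM, and compound 3 `Oc1c(Cc2ccccc2)cc(-c2ccccc2)c2ccccc12` gives 56 nM. On these numbers compound 3 stands second highest of the three, yet its gap to compound 2 and its gap to compound 1 both lie within the usual scatter of repeat measurements, so the three cannot be told apart on this read-out.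

Compound 4 `CS(=O)(=O)c1cc(Cc2ccccc2)c(O)c2ccccc12` has not yet been measured in this assay. It differs from compound 3 in one place: methylsulfonyl in place of phenyl on an aromatic carbon. Among the measured compounds shown here, no pair of measured compounds shows the effect of such a swap, and the three measured compounds differ from one another in other places, so no measured step guides the expectation. The estimate for compound 4 is therefore placed at a somewhat weaker inhibition than compound 3 shows, with a wide range. The expected step of a 2.7-fold higher number from compound 3 to compound 4 (0.43 log units; beyond the scatter) is modest. Compound 4 is thus expected to give 150 nM, within 40 nM to 600 nM.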

Compound 4, half-maximal inhibitory concentration: 40000 nM
Estimate against measurement, compound 4: 270-fold (2.43 log units) below, and the stated range ends below it.
By their numbers in this assay, from the lowest: compounds 2, 3 and 1 (each within the scatter of the next); then compound 4.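

In this assay, the aromatic carbon para to a hydroxy group proves highly sensitive to what it carries: methylsulfonyl in place of phenyl gives a 710-fold higher number from compound 3 to compound 4 (2.85 log units; beyond the scatter), a large loss of inhibition. The three earlier compounds lie within the scatter of one another, so they gave no sign that one change on the shared core could matter this much. Nothing at hand explains the size of this step.

With only phenyl and methylsulfonyl shown on this carbon, it remains open whether the loss comes with the arrival of methylsulfonyl or the departure of phenyl. A plain hydrogen, a methyl group or an amine on the same carbon could help separate those two readings.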